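A few compounds are considered here, and "the series" means these few. Any claim that something is new, unique, unknown or untested is made for them only; others in the source may bear on it.

Of the compounds shown here, three with a shared core have been measured in a functional assay on the whole organism for inhibition, with Rattus norvegicus as the target; on this read-out lower numbers stand for an effect already at smaller amounts and higher numbers for an effect only at larger amounts of compound. Compound 1 `NCCn1cc(C(=O)c2ccn3c2CSC3c2cccnc2)c2ccc(-c3ccc(F)cc3)cc21` gives 1.3 mg/kg in this assay. Compound 2 `CN(C)C(=O)Cn1cc(C(=O)c2ccn3c2CSC3c2cccnc2)c2ccc(-c3ccc(F)cc3)cc21` gives 0.12 mg/kg. Compound 3 `O=C(O)CCn1cc(C(=O)c2ccn3c2CSC3c2cccnc2)c2ccc(-c3ccc(F)cc3)cc21` gives 5.1 mg/kg, the highest number of the three; the step of a 3.9-fold higher number from compound 1 to compound 3 (0.59 log units; beyond the scatter) and the step of a 43-fold higher number from compound 2 to compound 3 (1.63 log units; beyond the scatter) both lie beyond the scatter, so compound 3 sits furthest from the small-dose end.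

Compound 4 `NNC(=O)n1cc(C(=O)c2ccn3c2CSC3c2cccnc2)c2ccc(-c3ccc(F)cc3)cc21` has not yet been measured. It differs from compound 3 in one place: aminocarbamoyl in place of 2-carboxyethyl on an aromatic nitrogen. Among the compounds with values here, two measured steps bear on this. The carboxy group of compound 3 went with the highest number, as seen in a 3.9-fold higher number from compound 1 to compound 3 (0.59 log units; beyond the scatter), while the amide of compound 2 went with the lowest, as seen in an 11-fold lower number from compound 1 to compound 2 (1.03 log units; beyond the scatter) and a 43-fold higher number from compound 2 to compound 3 (1.63 log units; beyond the scatter). Compound 4 carries an amide-like group and no carboxy, so a lower number than compound 3 is expected, probably of modest to large size, as the step of a 6.4-fold lower number from compound 3 to compound 4 (0.80 log units; beyond the scatter) expresses. Compound 4 is therefore estimated at 0.8 mg/kg in this assay, with a range from 0.2 mg/kg to 3.5 mg/kg.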

Compound 4, dose for half-maximal effect: 0.57 mg/kg
Beside the measured number, compound 4's estimate is 1.4-fold (0.15 log units) above it; the range from low to high includes it.
By their numbers in this assay, from the lowest: compound 2; then compound 4; then compound 1; then compound 3.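

The result shows that the aromatic nitrogen can carry aminocarbamoyl, a group with no saturated chain carbon, and still give a lower number in this assay than two of the earlier groups: 2-carboxyethyl (an 8.9-fold lower number from compound 3 to compound 4 (0.95 log units; beyond the scatter)) and 2-aminoethyl (a 2.3-fold lower number from compound 1 to compound 4 (0.36 log units; beyond the scatter)). Having a carbonyl-containing group at this position does not by itself match the lowest number, since (dimethylcarbamoyl)methyl remains lower (a 4.8-fold higher number from compound 2 to compound 4 (0.68 log units; beyond the scatter)). No available measurement accounts for these differences.

Compound 4 changes both the chain and the end group at once, so the compounds shown cannot separate the contribution of the carbonyl on the aromatic nitrogen from that of the terminal amino group. Going by these compounds, it remains open how a plain carbamoyl group, a methylated aminocarbamoyl group or a longer chain ending in dimethylcarbamoyl would compare.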